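Removing one methoxy from a weak 2,3-dimethoxyphenyl amide

This account rests on a few compounds, and the source may have more. Where it says the series, first, only, none or still open, it means among the compounds named here.

Measured in a functional assay on MDA-MB-231 cells (Homo sapiens), read by microscopy and transwell migration, with a stated time of 24 h; on this read-out higher numbers stand for weaker inhibition and lower numbers for stronger inhibition:
Compound 1 `COc1ccc(C(=O)Nc2nc(-c3cc(OC)c(OC)c(OC)c3)cs2)cc1`: > 25000 nM (a limit)
Compound 2 `COc1cc(-c2csc(NC(=O)c3cccc(OC)c3OC)n2)cc(OC)c1OC`: 15000 nM
Not yet measured:
Compound 3 `COc1ccccc1C(=O)Nc1nc(-c2cc(OC)c(OC)c(OC)c2)cs1`

The value of compound 1, > 25000 nM, is a limit of the assay and not a number. For the measured compounds named here, that leaves compound 2, at 15000 nM, with the only actual number in this assay, so it has no measured rank. Compound 3 differs from compound 2 by hydrogen in place of methoxy on an aromatic carbon, giving 2-methoxyphenyl from 2,3-dimethoxyphenyl. Going by the values given here, one measured step bears on this, an at least 1.6-fold lower number from compound 1 to compound 2 (0.22 log units; that floor lies within the scatter), where 2,3-dimethoxyphenyl replaced 4-methoxyphenyl on a carbonyl carbon. It is small, and its floor lies within the scatter. A slightly higher number is therefore expected, but nothing beyond the scatter. The expected change is a 1.2-fold higher number from compound 2 to compound 3 (0.08 log units; within the scatter). For compound 3 the estimated value is 18000 nM, with an expected range from 8000 nM to 30000 nM.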

Compound 3, half-maximal inhibitory concentration: 8500 nM
Compound 3: middle estimate off by 2.1-fold (0.33 log units), on the high side; low and high end bracket the measured number.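

In this assay, taking the methoxy away from the 2,3-dimethoxyphenyl amide gives a 1.8-fold lower number from compound 2 to compound 3 (0.25 log units; within the scatter), so the two amides cannot be told apart and this methoxy is not needed for the inhibition read here. For the compounds shown here, the single methoxy of the 2-methoxyphenyl amide, unlike that of the 4-methoxyphenyl amide, also yields the first step that lies beyond the scatter, an at least 2.9-fold lower number from compound 1 to compound 3 (0.46 log units; beyond the scatter). Compound 1 enters that step as a limit of the assay and not as a number, so the step gives only a floor: the limit of > 25000 nM in this assay, at which 1 of the 3 values shown sits.

Going by these compounds, what stays open is whether the remaining methoxy is itself needed, which a plain phenyl with hydrogen in its place would test. Also open, on these data alone, is whether a fluorine, a hydroxyl or an amine on that ring would shift the number beyond the scatter.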